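Methylsulfanyl in place of chloro: a series at its limit

This account rests on a few compounds, and the source may have more. Where it says the series, first, only, none or still open, it means among the compounds named here.

Compound 1 `C=C1[C@@H](O)[C@H](n2cnc3c(Cl)nc(N)nc32)O[C@@H]1CO` is the reference point. In a functional assay on MT4 cells (Homo sapiens) for inhibition (on this read-out higher numbers stand for weaker inhibition and lower numbers for stronger inhibition), compound 1 gives > 500000 nM, which is a limit and not a number. Compound 2 `C=C1[C@@H](O)[C@H](n2cnc3c(N(C)C)nc(N)nc32)O[C@@H]1CO` carries dimethylamino in place of chloro on an aromatic carbon. In this assay compound 2 gives > 500000 nM, again a limit. Going by the values given here, compound 1 therefore has no numeric position, and the only other reading offers none either: the data so far show (the limit of > 500000 nM in this assay, at which 2 of the 2 values shown sit).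

Compound 3 `C=C1[C@@H](O)[C@H](n2cnc3c(SC)nc(N)nc32)O[C@@H]1CO` carries methylsulfanyl in place of chloro on an aromatic carbon, at the same place on the shared core as the dimethylamino group of compound 2: methylsulfanyl in place of chloro on an aromatic carbon.

Among the compounds with values here, one measured step bears on this change, a step that the two limits leave unreadable from compound 1 to compound 2. It gives no size and no direction to carry over, so nothing supports expecting a step beyond the scatter in this assay. The expected step is a number no higher from compound 1 to compound 3 (the limit leaves the size open), and a reading that is again only a limit is the likeliest outcome. For compound 3 the estimated value is 500000 nM, with an expected range of 150000 nM to 1000000 nM.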

Compound 3, half-maximal inhibitory concentration: > 500000 nM
Compound 3: only a limit was reported (the forecaster's own chance of this, stated with the estimate: 80%); the middle value lies on the limit itself.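

In this assay compound 3 gives > 500000 nM, which is a limit and not a number. No step among compound 1, compound 2 and compound 3 can be read, and all three stand at the same limit: the limit of > 500000 nM in this assay, at which 3 of the 3 values shown sit.

The compounds shown leave open whether any group at this place on the shared core gives a numeric reading.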